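A few compounds are considered here, and "the series" means these few. Any claim that something is new, unique, unknown or untested is made for them only; others in the source may bear on it.

Compound 1, `Cn1c(-c2ccc([N+](=O)[O-])cc2)nc2cc(C(F)(F)F)ccc21`: > 100000 nM
Compound 2, `COc1ccc(-c2nc3cc(C(F)(F)F)ccc3[nH]2)c(OC)c1`: > 100000 nM

Among the compounds with values here, both compounds measured so far were run in an ADME assay on Vero cells (Chlorocebus sabaeus) for cytotoxicity; on this read-out higher numbers stand for lower toxicity in this test and lower numbers for higher toxicity in this test. In that test compound 1 gives > 100000 nM, which is a limit of the assay and not a number. Compound 2 likewise gives > 100000 nM, again a limit rather than a number. Compound 1 thus stands at the limit of > 100000 nM in this assay, at which 2 of the 2 values shown sit, and no ordering between the two measured compounds can be read from these values.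

Compound 3, `CC(=O)Nc1ccc(-c2nc3cc(C(F)(F)F)ccc3n2C)cc1`, remains to be measured in this assay. It differs from compound 1 in one place: acetamido in place of nitro on an aromatic carbon. Within the data shown here, no measured pair shows what such a change does in this assay, so the expectation rests on compound 1 alone. The step expected is a step that the limit leaves unreadable from compound 1 to compound 3, which is nothing beyond the scatter. Compound 3 is therefore estimated at 150000 nM, within a range from 50000 nM to 500000 nM, and most likely it will again be reported only as a limit.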

Compound 3, half-maximal cytotoxic concentration: > 100000 nM
Compound 3 was reported as a limit; the forecaster's own chance of this, stated with the estimate: 80%; the middle value lies beyond the limit too.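

In this assay, within the data shown here, compound 3, like compound 1, is reported only as a limit of the assay, so no step between compound 1 and compound 3 can be read. The compounds shown leave open what acetamido in place of nitro on an aromatic carbon does in this assay on this core.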